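The source may hold more compounds than are shown below. What is called first, only, known or untested is meant among the compounds shown, and "the series" means these compounds.

The measured compounds in an assay on isolated protein for inhibition of ribosomal protein S6 kinase alpha-1 (Homo sapiens), read by mobility shift assay, tested at 30 uM; on this read-out lower numbers stand for less inhibition and higher numbers for more inhibition at the one concentration tested (going by the name of the read-out):

Compound 1, `Nc1n[nH]c2cc(-c3ccccn3)[nH]c(=O)c12`: 24%
Compound 2, `Cc1cc2c(c(N)nn2C)c(=O)[nH]1`: 2%
Compound 3, `Cn1nc(N)c2c(=O)[nH]c(-c3ccccc3)cc21`: 8%

Compound 3 stands second highest of the three numbers in this assay. Its nearest neighbour is compound 2, whose number is lower by a margin that stays within the usual scatter; the furthest is compound 1, whose number is higher by a margin that lies beyond it. For the measured compounds named here, the one step between measured compounds, a number 6 percentage points higher from compound 2 to compound 3 (within the scatter), concerns phenyl in place of methyl and therefore does not touch the change now in question.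

Compound 4, `Cn1nc(N)c2c(=O)[nH]c(-c3ccccn3)cc21`, differs from compound 3 in one place: pyridin-2-yl in place of phenyl on an aromatic carbon. Going by the values given here, no measured step shows this exchange on the core shared by compound 3 and compound 4. Among the compounds with values here, the only compound that carries pyridin-2-yl is compound 1, and it gives the highest number of the three, but it also differs from compound 4 elsewhere, so its value can only be taken as a loose hint. Given that, the step of a number 6 percentage points higher from compound 3 to compound 4 (within the scatter) is expected to be small and upward, not clearly beyond the scatter. Compound 4 is therefore estimated to give 14% in this assay, with a range from 2% to 30%.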

Compound 4, a percentage reported as inhibition, at one concentration (the size of the read-out at that concentration, not a potency): 9%
For compound 4 the middle estimate is 5 percentage points above the measured one, within the range that was stated.
By their numbers in this assay, from the lowest: compounds 2, 3 and 4 (each within the scatter of the next); then compound 1.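

In this assay, putting pyridin-2-yl in place of phenyl on the aromatic carbon next to the ring nitrogen gives a number 1 percentage points higher from compound 3 to compound 4 (within the scatter), so on this core the entering ring nitrogen, with its one hydrogen-bond acceptor, brings no change that can be told from the scatter. The comparison with methyl at the same place reads the same way, a number 7 percentage points higher from compound 2 to compound 4 (within the scatter), so neither of the two aromatic groups stands apart from methyl here. The one clear difference lies elsewhere: with pyridin-2-yl held constant, methyl in place of hydrogen on the aromatic nitrogen gives a number 15 percentage points lower from compound 1 to compound 4 (beyond the scatter), so the higher number of compound 1 goes with that hydrogen and not with pyridin-2-yl alone.

The compounds shown leave open whether phenyl or methyl at this place would also give a higher number on the core with hydrogen on the aromatic nitrogen, and whether an amine or a carboxylic acid at this place would move the number at all. Nothing available bears on why the numbers fall as they do.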